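The compounds below may be only part of what the source reports. "The series", "measured", "known", "first", "only" and "open" are said of these compounds alone.

The measured compounds:
compound 1, `O=C(CC(c1ccccc1)C(C(=O)Nc1ccccn1)C(=O)Nc1ccccn1)c1ccccc1`, 28100 nM
compound 2, `O=C(CC(c1ccc(Cl)cc1Cl)C(C(=O)Nc1ccccn1)C(=O)Nc1ccccn1)c1ccccc1`, 13500 nM

Among the compounds with values here, in a functional assay on HeLa cells (Homo sapiens) for inhibition, read by MTT assay, with a stated time of 48 h (on this read-out lower numbers stand for stronger inhibition and higher numbers for weaker inhibition), compound 1 gives 28100 nM, the highest of the two numbers measured so far. Compound 2 gives 13500 nM in this assay and is the nearest neighbour of compound 1. Compound 3, `COc1ccc(C(CC(=O)c2ccccc2)C(C(=O)Nc2ccccn2)C(=O)Nc2ccccn2)cc1`, has not yet been measured. It differs from compound 1 by methoxy in place of hydrogen on an aromatic carbon, the new group sitting on an aromatic carbon of a six-membered aromatic ring of carbon only, para to a large group; read one bond further out, phenyl becomes 4-methoxyphenyl. Within the data shown here, the only measured step that bears on this change is a 2.1-fold lower number from compound 1 to compound 2 (0.32 log units; beyond the scatter), where 2,4-dichlorophenyl replaced phenyl on a saturated chain carbon bound to two saturated chain carbons. Methoxy is a different group from two chlorines, so that step is only a loose guide; it shows that altering this ring moves the number modestly rather than strongly. A small step in this assay, of uncertain direction and not larger than that seen with compound 2, is therefore expected. Compound 3 is estimated at 22000 nM, with a range from 8000 nM to 60000 nM, meaning an expected step of a 1.3-fold lower number from compound 1 to compound 3 (0.11 log units; within the scatter).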

Compound 3, half-maximal inhibitory concentration: "not active" (no number reported)
The entry for compound 3 holds no number, and the estimate cannot be compared.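

In this assay, within the data shown here, the entry for compound 3 reads "not active" with no number reported, so no step from compound 1 to compound 3 can be read. No measured property accounts for this entry. The compounds shown leave open how far methoxy on this ring moves the number relative to phenyl in compound 1.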